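Chloro to amino on the core of a urea series

The source may report more compounds than this note shows. Statements on the series, on what has been measured and on what is new or still open speak of the compounds shown alone.

Measured compounds:
compound 1, `Nc1nn(C(=O)Nc2ccc(Cc3ccccc3)cc2)c2ccccc12`: 22800 nM
compound 2, `Nc1nn(C(=O)Nc2ccc(Cc3ccccc3)cc2)c2ccc(Cl)cc12`: 14600 nM

In a functional assay on SNB-19 cells (Homo sapiens) for antiproliferative activity, read by sulforhodamine B assay, with a stated time of 48 h (on this read-out lower numbers stand for stronger inhibition of growth and higher numbers for weaker inhibition of growth), compound 1 gives 22800 nM and compound 2 gives 14600 nM. Compound 2 carries the lowest number of the two, yet the step of a 1.6-fold lower number from compound 1 to compound 2 (0.19 log units; within the scatter) lies within the scatter, so no order between the two is claimed. Compound 3, `Nc1ccc2c(c1)c(N)nn2C(=O)Nc1ccc(Cc2ccccc2)cc1`, differs from compound 2 by amino in place of chloro on an aromatic carbon. Among the measured compounds shown here, the single measured step, a 1.6-fold lower number from compound 1 to compound 2 (0.19 log units; within the scatter), exchanges hydrogen for chloro rather than chloro for amino, and it was itself within the scatter; it offers no direct reading of an amino group at that place. With nothing further to go on, the expected step in this assay is a 1.2-fold higher number from compound 2 to compound 3 (0.09 log units; within the scatter), that is, no change beyond the scatter, with the range widened for the missing precedent. Compound 3 is estimated at 18000 nM, with a range from 6000 nM to 55000 nM.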

Compound 3, concentration for 50% growth inhibition: 13900 nM
The estimate for compound 3 lay 1.3-fold (0.11 log units) above the measured number; measured number inside the range.
By their numbers in this assay, from the lowest: compounds 3, 2 and 1 (each within the scatter of the next).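

In this assay the exchange of chloro for amino at this place on the core gives a 1.1-fold lower number from compound 2 to compound 3 (0.02 log units; within the scatter) and so does not separate the two groups. Amino in place of hydrogen at the same aromatic carbon gives a 1.6-fold lower number from compound 1 to compound 3 (0.21 log units; within the scatter) and also stays within the scatter, so hydrogen, chloro and amino at this place can now be placed in no order. No measurement shown here accounts for these small steps.

From the compounds shown here alone, whether a carboxylic acid, a methoxy group or an acetamide at this place would move the number beyond the scatter remains open. Also open, going by these compounds, is whether these three groups would stay as close together on cell lines other than this one.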